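Cyclopropyl to tert-butyl on the hydroxy-acid side chain

A few compounds are considered here, and "the series" means these few. Any claim that something is new, unique, unknown or untested is made for them only; others in the source may bear on it.

Working notes on the series. Compound 1 `O=C(NCc1cc(Cl)ccc1-n1cnnn1)[C@@H]1[C@H]2C[C@H]2CN1C(=O)[C@H](O)CC1CC1` is measured in an ADME assay on liver for metabolic stability, with Liver microsome (Homo sapiens) as the target, read by LC-MS, using microsomes; a lower number here means slower removal, a higher number faster removal of the compound; in this assay compound 1 gives < 14 mL.min-1.g-1, which is a limit of the assay and not a number. Compound 2 `CC(C)(C)[C@@H](O)C(=O)N1OCC[C@H]1C(=O)NCc1cc(Cl)ccc1-n1cnnn1` gives < 12 mL.min-1.g-1 in this assay, again a limit. Compound 3 `O=C(NCc1cc(Cl)ccc1-n1cnnn1)[C@@H]1C[C@@H]2C[C@@H]2N1C(=O)[C@H](O)CC1CC1` gives < 12 mL.min-1.g-1 in this assay, also a limit. So all three measured compounds sit at the floor of the assay, and compound 1 cannot be placed against the other two beyond that; no step between measured compounds is resolved here.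

The step of interest runs from compound 1 to the unmeasured compound 4 `CC(C)(C)C[C@@H](O)C(=O)N1C[C@@H]2C[C@@H]2[C@H]1C(=O)NCc1cc(Cl)ccc1-n1cnnn1`. The change is tert-butyl in place of cyclopropyl on a saturated chain carbon, two bonds along the chain from a carbonyl carbon and an oxygen on a saturated carbon. Nothing in the measured set resolves a step of this kind, since every value shown is a limit.

Expectation: compound 4 is expected to remain near the floor of this assay, with a step from compound 1 to compound 4 of a step that the limit leaves unreadable from compound 1 to compound 4, that is, none beyond the scatter. The estimate for compound 4 in this assay is 10 mL.min-1.g-1, with a range from 4 mL.min-1.g-1 to 28 mL.min-1.g-1, and a good chance that the assay again reports only a limit.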

Compound 4, intrinsic clearance in microsomes: 20 mL.min-1.g-1
Compound 4: middle estimate off by 2.0-fold (0.30 log units), on the low side; the range from low to high includes it.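

In this assay, among these compounds, compound 4 gives 20 mL.min-1.g-1, the only value shown that is a number and not a limit, so tert-butyl at this position, on a saturated chain carbon, two bonds along the chain from a carbonyl carbon and an oxygen on a saturated carbon, is the first change here to give a readable result. Compound 1 gives < 14 mL.min-1.g-1, which is a limit. Read against that limit, the change gives an at least 1.4-fold higher number from compound 1 to compound 4 (0.15 log units; that floor lies within the scatter), so the step has only a floor and its true size stays unknown, and the comparison rests on this: the limit of < 14 mL.min-1.g-1 in this assay, at which 1 of the 4 values shown sits.

Open, from the compounds shown here alone, is how the read-out behaves with other groups at this position on the core of compound 1, such as isopropyl, cyclobutyl or a longer chain, and whether any of them gives a number clear of the scatter from compound 1. Compound 2 and compound 3 differ from compound 4 in more than one place and sit at limits, so no further step can be read.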